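Cyclohexyl esters: removing the benzoyl group in the series

The compounds below may be only part of what the source reports. "The series", "measured", "known", "first", "only" and "open" are said of these compounds alone.

Measured so far, an ADME assay on WI-38 cells (Homo sapiens) for inhibition, read by MTT assay, with a stated time of 72 h; on this read-out higher numbers stand for weaker inhibition and lower numbers for stronger inhibition:
compound 1, `O=C(OC1(C(=O)Nc2ccc([N+](=O)[O-])cc2)CCCCC1)c1ccc(C(F)(F)F)cc1`: 185 nM
compound 2, `Cc1ccc(C(=O)OC2(C(=O)Nc3ccc([N+](=O)[O-])cc3)CCCCC2)cc1`: 32 nM
compound 3, `O=C(OC1(C(=O)Nc2ccc([N+](=O)[O-])cc2)CCCCC1)c1ccccc1`: 246 nM

Compound 3 gives the highest of the three numbers in this assay. Its nearest neighbour is compound 1, a step within the scatter a 1.3-fold higher number from compound 1 to compound 3 (0.12 log units; within the scatter); its furthest is compound 2 a 7.7-fold higher number from compound 2 to compound 3 (0.89 log units; beyond the scatter). The other step among the measured compounds, a 5.8-fold lower number from compound 1 to compound 2 (0.76 log units; beyond the scatter), is likewise a change of the substituent on the benzoyl ring.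

Compound 4, `O=C(Nc1ccc([N+](=O)[O-])cc1)C1(O)CCCCC1`, differs from compound 3 by hydrogen in place of benzoyl on an oxygen on a saturated carbon. None of the three measured steps bears directly on this: all of them exchange a single substituent on the benzoyl ring, whereas here the whole benzoyl group leaves and only the hydroxy remains. Among the measured compounds shown here, the measured steps show only that changes at this part of the molecule shift the number modestly, in either direction. The step to compound 4 is larger in kind, so the direction is open; a rise in the number is taken as somewhat more likely, and the range is set wide. For compound 4 the estimate in this assay is 800 nM, range 150 nM to 5000 nM, an expected step of a 3.3-fold higher number from compound 3 to compound 4 (0.51 log units; beyond the scatter).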

Compound 4, half-maximal inhibitory concentration: 1220 nM
Estimate against measurement, compound 4: 1.5-fold (0.18 log units) below, and the stated range covers the measured number.
By their numbers in this assay, from the lowest: compound 2; then compounds 1 and 3 (each within the scatter of the next); then compound 4.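

In this assay, hydroxy in place of benzoyloxy on this oxygen gives a shift beyond the scatter (a 5.0-fold higher number from compound 3 to compound 4 (0.70 log units; beyond the scatter)), so the position responds to loss of the whole benzoyl group and not only to exchange of a substituent on its ring. The same removal counted from the methyl-bearing ester is a far larger step (a 38-fold higher number from compound 2 to compound 4 (1.58 log units; beyond the scatter)), so the size of the loss depends on which benzoyl group leaves. No measurement at hand accounts for either step.

As far as these compounds go, it remains open whether the benzoyl ring itself matters at this oxygen, or whether a smaller ester such as acetyl, or an amine in place of the hydroxy, would read like compound 3 or like compound 4. Also open, from the compounds shown here alone, is whether a methoxy or a chlorine on the benzoyl ring would follow methyl or trifluoromethyl.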